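From iodo to methoxy: estimating growth inhibition

The compounds below may be only part of what the source reports. "The series", "measured", "known", "first", "only" and "open" are said of these compounds alone.

Measured so far in a functional assay on UO-31 cells (Homo sapiens) for inhibition; on this read-out lower numbers stand for stronger inhibition of growth and higher numbers for weaker inhibition of growth:
- Compound 1 `NC(=O)c1cc(Cl)ccc1NC(=O)COc1ccccc1` gives 17500 nM
- Compound 2 `NC(=O)c1cc(I)ccc1NC(=O)COc1ccccc1` gives 2870 nM

Compound 2 stands lowest of the two numbers, so it is the stronger growth inhibitor of the pair. For the measured compounds named here, only one measured step bears on it: a 6.1-fold lower number from compound 1 to compound 2 (0.79 log units; beyond the scatter), where iodo took the place of chloro on an aromatic carbon. That step is modest but beyond the scatter, and it shows that the group at this place can move the number.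

Compound 3 `COc1ccc(NC(=O)COc2ccccc2)c(C(N)=O)c1` keeps the shared core but has methoxy in place of iodo on an aromatic carbon, para to a large group (methoxy in place of iodo on an aromatic carbon). Going by the values given here, no compound with methoxy has been measured, so the guidance is thin. Among the compounds with values here, compound 2 holds the lowest number so far (2870 nM), so a rise is expected more than a further fall. The expected change is a 3.1-fold higher number from compound 2 to compound 3 (0.50 log units; beyond the scatter) in this assay, towards weaker inhibition of growth. The estimated value for compound 3 is 9000 nM, with an expected range from 3000 nM to 27000 nM (a wide range, given a single guiding step).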

Compound 3, concentration for 50% growth inhibition: 8720 nM
For compound 3 the middle estimate is 1.0-fold (0.01 log units) above the measured one; the measured number falls inside the stated range.
By their numbers in this assay, from the lowest: compound 2; then compounds 3 and 1 (each within the scatter of the next).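

In this assay, replacing iodo with methoxy gives a 3.0-fold higher number from compound 2 to compound 3 (0.48 log units; beyond the scatter), so compound 2 now stands apart from two other groups at this position rather than from chloro alone. Replacing chloro with methoxy gives a 2.0-fold lower number from compound 1 to compound 3 (0.30 log units; within the scatter), so compound 1 and compound 3 cannot be told apart in this read-out, even though their groups differ. The advantage seen so far therefore belongs to iodo in particular, not to every change away from chloro, although nothing available here bears on why these groups give the numbers they do.

As far as these compounds go, three groups at a single position are too few to show what sets the number, so it remains open whether bromo, an amine or a longer chain such as ethoxy would fall near compound 2 or alongside compound 1 and compound 3. From the compounds shown here alone, it is also open whether iodo would keep its lead if another part of the shared core were changed, since all three compounds differ only at this one position.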